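Dibutylamino analogue: chloro to fluoro step on the carbocyclic ring

This account rests on a few compounds, and the source may have more. Where it says the series, first, only, none or still open, it means among the compounds named here.

Measured compounds:
compound 1 `N#Cc1c(F)c(Cl)c2nc(N)nc(N)c2c1F`, 0.14 ug/mL
compound 2 `N#Cc1c(F)c(F)c2nc(N)nc(N)c2c1F`, 8 ug/mL
compound 3 `CCCCNc1c(C#N)c(NCCCC)c2c(N)nc(N)nc2c1Cl`, 0.6 ug/mL

All numbers come from a functional assay on SK-OV-3 cells (Homo sapiens) for cytotoxicity, read by MTT assay; on this read-out lower numbers stand for stronger inhibition and higher numbers for weaker inhibition. Compound 1 sits at the low end of the three, compound 2 at the high end, and compound 3 between them. The shared core of compound 1 and compound 3 is not broken down here; the two differ in more than one place.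

Among the compounds with values here, the single step that is measured within the set is fluoro in place of chloro on an aromatic carbon: from compound 1 to compound 2 this gives a 57-fold higher number from compound 1 to compound 2 (1.76 log units; beyond the scatter).

Compound 4 `CCCCNc1c(C#N)c(NCCCC)c2c(N)nc(N)nc2c1F` is not yet measured. It carries the same kind of change relative to compound 3, (fluoro in place of chloro on an aromatic carbon), but the surroundings of the place differ: in compound 1 the carbon is ortho and para to a fluoro group, in compound 3 it is ortho and para to a butylamino group. Within the data shown here, a large rise is expected, a 17-fold higher number from compound 3 to compound 4 (1.22 log units; beyond the scatter), because the only measured instance of this kind of change gave a 57-fold higher number from compound 1 to compound 2 (1.76 log units; beyond the scatter). The surroundings differ, so a somewhat smaller step is assumed. Compound 4 is expected at 10 ug/mL, with a range from 2 ug/mL to 40 ug/mL.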

Compound 4, half-maximal inhibitory concentration: 1.6 ug/mL
Estimate against measurement, compound 4: 6.3-fold (0.80 log units) above; measured number below the stated range.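

In this assay, fluoro in place of chloro on an aromatic carbon gives a higher number on both cores, but the size of the step does not carry over from one core to the other: the same change on two cores in this assay, a 57-fold higher number (1.76 log units; beyond the scatter) from compound 1 to compound 2 and a 2.7-fold higher number (0.43 log units; beyond the scatter) from compound 3 to compound 4, 21-fold (1.33 log units) apart, beyond the scatter of two such steps. With a butylamino group ortho and another para to the carbon, the change gives a 2.7-fold higher number from compound 3 to compound 4 (0.43 log units; beyond the scatter), so the two pairs share a direction but not a size. Two pairs cannot show which difference between the cores sets the size, as the fluoro groups of compound 1 and the butylamino groups of compound 3 differ together, and they do not predict the step on any third core.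

Still open, as far as these compounds go, is how a core carrying one butylamino group and one fluoro group would respond to the same change, which would begin to separate those differences. Also open, from the compounds shown here alone, is how bromo or a plain hydrogen on that carbon, or a longer chain such as hexylamino in place of butylamino, would read on this core.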